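Trimming the Chain: From Compound 1 to Compound 3

A few compounds are considered here, and "the series" means these few. Any claim that something is new, unique, unknown or untested is made for them only; others in the source may bear on it.

Measured compounds:
compound 1, `CCCCCOCNc1n[n+]([O-])c2ccccc2[n+]1[O-]`: 14500 nM
compound 2, `CCCCCOCNc1n[n+]([O-])c2cc(OC)ccc2[n+]1[O-]`: 7110 nM

Among the two numbers recorded in a functional assay on K562 cells (Homo sapiens) for cytotoxicity, read by MTT assay, with a stated time of 72 h (on this read-out higher numbers stand for weaker inhibition and lower numbers for stronger inhibition), compound 1 stands highest; its nearest neighbour is compound 2, reached by a 2.0-fold lower number from compound 1 to compound 2 (0.31 log units; beyond the scatter), the one change a methoxy in place of hydrogen on an aromatic carbon. Compound 3, `CCCOCNc1n[n+]([O-])c2ccccc2[n+]1[O-]`, has not yet been measured. It differs from compound 1 by hydrogen in place of ethyl on a saturated chain carbon, three bonds along the chain from an oxygen on a saturated carbon. Among the compounds with values here, the single measured step alters the aromatic ring and leaves the chain untouched, so no measured step speaks directly to this change. With nothing in the recorded steps pointing either way, the expectation is a step that stays within the scatter, in no particular direction. The estimate for compound 3 in this assay is therefore 14500 nM, with an expected range from 5000 nM to 42000 nM. As a step this estimate means an expected no change at the digits printed from compound 1 to compound 3 (within the scatter).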

Compound 3, half-maximal inhibitory concentration: 17600 nM
Compound 3: middle estimate off by 1.2-fold (0.08 log units), on the low side, and the stated range covers the measured number.
By their numbers in this assay, from the lowest: compound 2; then compounds 1 and 3 (each within the scatter of the next).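

Within the data shown here, the step of a 1.2-fold higher number from compound 1 to compound 3 (0.08 log units; within the scatter) in this assay is the first measured change on the chain rather than on the aromatic ring, and it leaves the two compounds inseparable. Cut one bond further out, the same difference reads pentyl to propyl, and at this place that swap does not move the number beyond the scatter, whereas the step of a 2.0-fold lower number from compound 1 to compound 2 (0.31 log units; beyond the scatter) on the aromatic ring remains the only one that does. Nothing available bears on why the chain change reads this way.

The compounds shown leave open whether a longer chain, or an amine or a carboxylic acid carried on the chain, would read differently at this place. They also leave open whether methoxy on the aromatic ring would give the same step when added to compound 3.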